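A few compounds are considered here, and "the series" means these few. Any claim that something is new, unique, unknown or untested is made for them only; others in the source may bear on it.

Measured in a functional assay on HepG2 cells (Homo sapiens) for antiproliferative activity, read by MTT assay, with a stated time of 72 h; on this read-out higher numbers stand for weaker inhibition and lower numbers for stronger inhibition:
- compound 1 `O=C(N/N=C/c1ccccc1)Nc1ccc(Oc2ccnc3[nH]ccc23)c(F)c1`: 640 nM
- compound 2 `O=C(N/N=C/c1cccc(Br)c1)Nc1ccc(Oc2ccnc3[nH]ccc23)c(F)c1`: 660 nM
- compound 3 `O=C(N/N=C/c1ccc(F)cc1)Nc1ccc(Oc2ccnc3[nH]ccc23)c(F)c1`: 3880 nM

Compound 3 has the highest number of the three, which makes it the weakest inhibitor here. The next compound, compound 4 `N#Cc1ccc(/C=N/NC(=O)Nc2ccc(Oc3ccnc4[nH]ccc34)c(F)c2)cc1`, has not yet been measured. It carries cyano in place of fluoro on an aromatic carbon, para to a large group: cyano in place of fluoro on an aromatic carbon.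

Going by the values given here, two measured steps bear on this change. Adding the fluoro to the plain phenyl gave a 6.1-fold higher number from compound 1 to compound 3 (0.78 log units; beyond the scatter), a modest weakening. Adding a bromo, as in the 3-bromophenyl compound, gave a 1.0-fold higher number from compound 1 to compound 2 (0.01 log units; within the scatter), so not every added group costs activity. Neither step tests a cyano, so the direction remains uncertain. The expectation in this assay is only a small step towards a lower number, with compound 1 at 640 nM as the reference without an added group. The estimated change is a 1.9-fold lower number from compound 3 to compound 4 (0.29 log units; within the scatter). For compound 4 the expected value is 2000 nM, with an estimated range of 600 nM to 6500 nM.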

Compound 4, half-maximal inhibitory concentration: 850 nM
Beside the measured number, compound 4's estimate is 2.4-fold (0.37 log units) above it; low and high end bracket the measured number.
By their numbers in this assay, from the lowest: compounds 1, 2 and 4 (each within the scatter of the next); then compound 3.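

At this place, para to a large group, the identity of the group matters in this assay: cyano in place of fluoro gives a 4.6-fold lower number from compound 3 to compound 4 (0.66 log units; beyond the scatter), so the loss seen with fluoro is not shared by every group there. Cyano in place of hydrogen gives a 1.3-fold higher number from compound 1 to compound 4 (0.12 log units; within the scatter), and 4-cyanophenyl in place of 3-bromophenyl gives a 1.3-fold higher number from compound 2 to compound 4 (0.11 log units; within the scatter), which leaves compound 3 as the only one of the four that stands apart. Nothing available explains why fluoro and cyano differ at this place.

The compounds shown leave open whether an amine, a methoxy group or a carboxylic acid at this place would match cyano or fluoro. They also leave open how cyano would fare on the phenyl ring at the place that carries bromo in 3-bromophenyl.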